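Pyrazole amide series: carbamoyl to acetamido swap

This account rests on a few compounds, and the source may have more. Where it says the series, first, only, none or still open, it means among the compounds named here.

Compound 3 `Cc1cc(C(=O)Nc2ccccn2)nn1Cc1cc(Cl)ccc1OCc1ccccc1` in an assay on CHO-K1 cells for displacement of a labelled ligand from prostaglandin E2 receptor EP1 subtype (Homo sapiens) (a lower number here means a stronger inhibitor, a higher number a weaker inhibitor), gives 126 nM. Compound 1 `Cc1cc(C(=O)NC(C)C)nn1Cc1cc(Cl)ccc1OCc1ccccc1` gives 126 nM, level with compound 3 at the digits printed, and compound 2 `Cc1cc(C(=O)Nc2cccc(F)c2)nn1Cc1cc(Cl)ccc1OCc1ccccc1` gives 200 nM; together compounds 1 and 3 hold the lowest numbers of the three, with a 1.6-fold lower number from compound 2 to compound 3 (0.20 log units; within the scatter) and a 1.6-fold higher number from compound 1 to compound 2 (0.20 log units; within the scatter) both within the scatter, as is no change at the digits printed from compound 1 to compound 3 (within the scatter). Within the data shown here, every measured step so far exchanges only the group on the amide-type nitrogen, leaving the carbamoyl on the shared core in place.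

Compound 4 `CC(=O)Nc1cc(C)n(Cc2cc(Cl)ccc2OCc2ccccc2)n1` differs from compound 3 by acetamido in place of (pyridin-2-yl)carbamoyl on an aromatic carbon. Among the measured compounds shown here, no measured step removes the carbamoyl itself, so none bears directly on this change; the tolerance seen across isopropyl, 3-fluorophenyl and pyridin-2-yl on the amide-type nitrogen is the only guide, and it does not cover the loss of that nitrogen's substituent. A moderately higher number is therefore expected, with wide uncertainty, as a 3.2-fold higher number from compound 3 to compound 4 (0.50 log units; beyond the scatter). Compound 4 is estimated at 400 nM, in the range 80 nM to 2000 nM.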

Compound 4, half-maximal inhibitory concentration: 316 nM
Beside the measured number, compound 4's estimate is 1.3-fold (0.10 log units) above it; the range from low to high includes it.
By their numbers in this assay, from the lowest: compounds 1, 3, 2 and 4 (each within the scatter of the next, the first and the last beyond it).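

Among these compounds, exchanging the carbamoyl on this aromatic carbon gives the first steps in this assay that are printed as beyond the scatter: a 2.5-fold higher number from compound 3 to compound 4 (0.40 log units; beyond the scatter) and a 2.5-fold higher number from compound 1 to compound 4 (0.40 log units; beyond the scatter) are both modest, while a 1.6-fold higher number from compound 2 to compound 4 (0.20 log units; within the scatter) stays within it. The position therefore accepts acetamido, which has no ring and fewer heavy atoms than the groups it replaces, and compound 4 still gives 316 nM with no large loss against any of the three carbamoyl compounds. The data shown offer no measured reason for these steps.

Going by these compounds, it remains open whether the modest steps follow from the reversed order of carbonyl and nitrogen on the aromatic carbon or from the smaller group. A benzamido group or a free amine at this carbon would help separate the two.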